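Phenethyl for Methoxyphenyl in a Bitter Taste Receptor Series

A few compounds are considered here, and "the series" means these few. Any claim that something is new, unique, unknown or untested is made for them only; others in the source may bear on it.

Measured compounds:
compound 1, `Cc1noc(C)c1Cn1cc(NC(=O)c2ccccc2)cn1`, gives 1700 nM in a functional assay on cells for antagonist activity at taste receptor type 2 member 8 (Homo sapiens), read by FLIPR and calcium flux, with a stated time of 100 s; on this read-out higher numbers stand for weaker inhibition and lower numbers for stronger inhibition
compound 2, `COc1cccc(C(=O)Nc2cnn(Cc3c(C)noc3C)c2)c1`, gives 700 nM in this assay

For the measured compounds named here, compound 2 holds the lowest of the two numbers in this assay; its nearest neighbour is compound 1, and the one measured step, a 2.4-fold lower number from compound 1 to compound 2 (0.39 log units; beyond the scatter), separates them. Compound 3, `Cc1noc(C)c1Cn1cc(NC(=O)CCc2ccccc2)cn1`, has not yet been measured. It differs from compound 2 by phenethyl in place of 3-methoxyphenyl on a carbonyl carbon. Going by the values given here, only the step from compound 1 to compound 2 bears on this change, and only in part: it shows that the methoxy group is lost at a modest cost, whereas nothing measured here speaks to the exchange of an aromatic ring bonded directly to the carbonyl for a phenethyl chain. The expectation is therefore anchored on compound 1, which gives 1700 nM. With the methoxy gone, compound 3 is expected to return at least to that level, with wide uncertainty added for the untested chain. The estimated step is a 3.6-fold higher number from compound 2 to compound 3 (0.55 log units; beyond the scatter). Compound 3 is estimated at 2500 nM, within a range of 900 nM to 7000 nM.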

Compound 3, half-maximal inhibitory concentration: 400 nM
Estimate against measurement, compound 3: 6.3-fold (0.80 log units) above; measured number below the stated range.
By their numbers in this assay, from the lowest: compounds 3 and 2 (each within the scatter of the next); then compound 1.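

Phenethyl in place of 3-methoxyphenyl on a carbonyl carbon gives a 1.8-fold lower number from compound 2 to compound 3 (0.24 log units; within the scatter) in this assay, so this position accepts a phenethyl chain as well as a directly attached aromatic ring, and the two groups cannot be told apart on this read-out even though the oxygen of the methoxy group is absent from phenethyl. Phenethyl in place of phenyl at the same carbon gives a 4.3-fold lower number from compound 1 to compound 3 (0.63 log units; beyond the scatter), which shows that a change of the group itself, and not only a methoxy on its aromatic ring, can lower the number from the level of compound 1. Nothing available here accounts for either step.

As far as these compounds go, whether a methoxy on the aromatic ring of the phenethyl group would lower the number again, as it did in a 2.4-fold lower number from compound 1 to compound 2 (0.39 log units; beyond the scatter), remains open. It also remains open how a benzyl group, a longer chain such as phenylpropyl, or a phenethyl chain carrying an amine or a carboxylic acid would read at this carbonyl carbon in this assay, and so how far the trend among these three compounds extends.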